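The source may report more compounds than this note shows. Statements on the series, on what has been measured and on what is new or still open speak of the compounds shown alone.

Measured so far in a functional assay on MKN-45 cells (Homo sapiens) for inhibition, with a stated time of 72 h; on this read-out lower numbers stand for stronger inhibition and higher numbers for weaker inhibition
- compound 1 `COc1cc(C(=O)c2ccc3cc[nH]c3c2)cc(OC)c1OC` gives 480 nM
- compound 2 `CCCn1ccc2cc(C(=O)c3cc(OC)c(OC)c(OC)c3)ccc21` gives 680 nM

Compound 2 stands level with compound 1, since their two values lie within the scatter of each other. Compound 3 `COc1cc(C(=O)c2ccc3c(ccn3CC(=O)O)c2)cc(OC)c1OC` differs from compound 2 by carboxy in place of ethyl on a saturated chain carbon bound to an aromatic nitrogen. Going by the values given here, no measured compound carries a carboxy group, so the series offers no direct precedent. The expected step in this assay is a 4.4-fold higher number from compound 2 to compound 3 (0.64 log units; beyond the scatter), toward weaker inhibition and beyond the scatter. For compound 3 the estimated value is 3000 nM (range 700 nM to 15000 nM).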

Compound 3, half-maximal inhibitory concentration: 396 nM
Estimate against measurement, compound 3: 7.6-fold (0.88 log units) above, outside the stated range (below it).
By their numbers in this assay, from the lowest: compounds 3, 1 and 2 (each within the scatter of the next).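

In this assay, carboxy in place of ethyl on a saturated chain carbon bound to an aromatic nitrogen gives a 1.7-fold lower number from compound 2 to compound 3 (0.23 log units; within the scatter), so compound 3 stands level with compound 2. Going by these compounds alone, the position therefore accepts the first carboxy group, and propyl to carboxymethyl leaves the read-out within the scatter. No measurement at hand explains this result.

From the compounds shown here alone, whether an amine, an amide or a methyl ester would fare the same at this position stays open. So does a longer chain ending in a carboxylic acid.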